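The compounds below may be only part of what the source reports. "The series", "measured", "known", "first", "only" and "open" are said of these compounds alone.

Compound 1 `CC(C)Sc1nnc(-c2c(CNC3CC3)c3ccccc3n2C)n1-c1ccccc1` was examined in a physicochemical assay for lipophilicity (a lower number here means a more polar compound, a higher number a more lipophilic compound), and gives 4.81. Going by the values given here, only one other compound has been measured: compound 2 `COc1cccc(CNCc2c(-c3nnc(SC(C)C)n3-c3ccccc3)n(C)c3ccc(F)cc23)c1`, which in this assay gives 6.42. Compound 1 therefore stands at the lower of the two numbers, and the gap to compound 2 lies beyond the usual scatter of the method. Among the compounds with values here, compound 2 differs from compound 1 in more than one place, so no single structural step between measured compounds can be read off these data.

The unmeasured compound 3 `CC(C)Sc1nnc(-c2c(CNc3nc4ccccc4[nH]3)c3ccccc3n2C)n1-c1ccccc1` departs from compound 1 in one place: 1H-benzimidazol-2-yl in place of cyclopropyl on an amine nitrogen. Within the data shown here, whether this change raises or lowers the number cannot be checked against a measured pair, since no comparable step is available. The change replaces a small carbon-only ring with a larger aromatic system that brings one donor and one acceptor, and on balance compound 3 is expected to come out somewhat higher than compound 1 in this assay, with a step of a number 0.79 log units higher from compound 1 to compound 3 (beyond the scatter) that should exceed the scatter. The estimate for compound 3 is 5.6, expected to fall between 4.9 and 6.4.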

Compound 3, partition coefficient: 5.94
Estimate against measurement, compound 3: 0.34 log units below; low and high end bracket the measured number.
By their numbers in this assay, from the lowest: compound 1; then compound 3; then compound 2.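

In this assay, going by these compounds alone, the exchange of cyclopropyl for 1H-benzimidazol-2-yl on the amine nitrogen gives the first step that can be read at one place, a number 1.13 log units higher from compound 1 to compound 3 (beyond the scatter), and it shows that the number responds strongly to what this nitrogen carries. The entering group has a hydrogen-bond donor and a hydrogen-bond acceptor where cyclopropyl has neither, yet the number still rises in this pair, so those counts alone do not set its direction here. The measurements shown offer nothing that would explain the size or direction of this step.

As far as these compounds go, it remains open whether a phenyl, a 1H-imidazol-2-yl or a saturated amine such as piperidinyl on the same nitrogen would give a number closer to that of compound 1 or to that of compound 3, which would help separate the contribution of the fused benzene ring from that of the two ring nitrogens. From the compounds shown here alone, it is also open whether the same exchange would give a step of similar size in a compound that differs elsewhere, for instance one carrying a fluorine on the shared core.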